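Moving the methyl on the sulfonyl aryl group

The compounds below may be only part of what the source reports. "The series", "measured", "known", "first", "only" and "open" are said of these compounds alone.

Compound 1 `CN(c1ccc(C(O)(C(F)(F)F)C(F)(F)F)cc1)S(=O)(=O)c1ccccc1` — an ADME assay on Li23 cells (Homo sapiens) for cytotoxicity, read by WST assay; on this read-out higher numbers stand for lower toxicity in this test and lower numbers for higher toxicity in this test: 16000 nM
Compound 2 `Cc1ccccc1S(=O)(=O)N(C)c1ccc(C(O)(C(F)(F)F)C(F)(F)F)cc1` — this assay: 12000 nM

Among these two numbers in this assay, compound 2 carries the smaller one, but its only neighbour is compound 1 and the step of a 1.3-fold lower number from compound 1 to compound 2 (0.12 log units; within the scatter) lies within the scatter, so the pair cannot be told apart on this read-out. Compound 3 `Cc1cccc(S(=O)(=O)N(C)c2ccc(C(O)(C(F)(F)F)C(F)(F)F)cc2)c1` is not yet measured. It differs from compound 2 by 3-methylphenyl in place of 2-methylphenyl on a sulfonyl sulfur. Among the measured compounds shown here, the single measured step bearing on this change is a 1.3-fold lower number from compound 1 to compound 2 (0.12 log units; within the scatter), which shows that adding the methyl to the sulfonyl aryl group did not move the number beyond the scatter; no measured pair shows what relocating that methyl does. On that footing, compound 3 is expected to show a 1.1-fold higher number from compound 2 to compound 3 (0.03 log units; within the scatter), a shift that stays within the scatter. Compound 3 is therefore estimated at 13000 nM in this assay, with a range from 6000 nM to 28000 nM.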

Compound 3, half-maximal cytotoxic concentration: 11000 nM
Compound 3: the middle estimate sits 1.2-fold (0.07 log units) above what was measured; low and high end bracket the measured number.
By their numbers in this assay, from the lowest: compounds 3, 2 and 1 (each within the scatter of the next).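

In this assay, among the compounds shown here, the methyl had so far only been added. Relocating it, with 3-methylphenyl in place of 2-methylphenyl on the sulfonyl sulfur, gives a 1.1-fold lower number from compound 2 to compound 3 (0.04 log units; within the scatter) and so leaves the number within the scatter. Set against compound 1, which lacks this methyl, the new placement gives a 1.5-fold lower number from compound 1 to compound 3 (0.16 log units; within the scatter) and also stays within the scatter, so neither methyl placement shown separates from compound 1 on this read-out. Nothing available offers a reason for this result.

The compounds shown leave open whether a group other than methyl on this aryl ring, such as a methoxy group, a chlorine or an amine, would move the number beyond the scatter. They also leave open what a longer chain in place of the methyl on the sulfonamide nitrogen would do.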